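Exchanging one ring group on a carbonyl carbon

A few compounds are considered here, and "the series" means these few. Any claim that something is new, unique, unknown or untested is made for them only; others in the source may bear on it.

In a functional assay on CAL-51 cells (Homo sapiens) for inhibition, read by luminescence, with a stated time of 3 days (on this read-out higher numbers stand for weaker inhibition and lower numbers for stronger inhibition), compound 1 (`CCc1cccc(CC)c1NC(=O)c1ccn(-c2nc(Nc3ccc(N4CCC(N5CCN(C)CC5)CC4)cc3OC)nc3[nH]ccc23)c1`) gives 6 nM and compound 2 (`CCc1cccc(CC)c1N1CCn2cc(-c3nc(Nc4ccc(N5CCC(N6CCN(C)CC6)CC5)cc4OC)nc4[nH]ccc34)cc2C1=O`) gives 9 nM while compound 3 (`CCc1cccc(CC)c1N1CCn2cc(-c3nc(Nc4ccc(N5CCC(C(=O)N6CCN(C)CC6)CC5)cc4OC)nc4[nH]ccc34)cc2C1=O`) gives 5 nM on the same read-out. Compound 3 thus stands within the scatter of both other compounds, and no order can be drawn between it and either of them.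

Compound 4 (`CCc1cccc(CC)c1N1CCn2cc(-c3nc(Nc4ccc(N5CCC(C(=O)N6CC7(CN(C)C7)C6)CC5)cc4OC)nc4[nH]ccc34)cc2C1=O`) differs from compound 3 in one place only, on a carbonyl carbon whose other neighbour is a saturated ring carbon (a group of 8 heavy atoms (6 carbon, 2 nitrogen; 2 four-membered non-aromatic rings with 1 hetero atom each) in place of a group of 7 heavy atoms (5 carbon, 2 nitrogen; one six-membered non-aromatic ring with 2 hetero atoms), on a carbonyl carbon). The group that enters carries 2 four-membered non-aromatic rings with 1 hetero atom each, where the group that leaves has one six-membered non-aromatic ring with 2 hetero atoms.

Going by the values given here, only one measured step touches this part of the molecule, the exchange of 4-methylpiperazin-1-yl for (4-methylpiperazin-1-yl)carbonyl on a saturated ring carbon. Among the compounds with values here, no measured compound yet varies the group on the carbonyl itself, so the evidence is indirect. Because a 1.8-fold lower number from compound 2 to compound 3 (0.26 log units; within the scatter) stayed within the scatter, no step beyond the scatter is expected in this assay for this exchange. The expected step is a 1.2-fold higher number from compound 3 to compound 4 (0.08 log units; within the scatter) on this reasoning. The estimated value for compound 4 is 6 nM (expected range 2.5 nM to 15 nM).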

Compound 4, half-maximal inhibitory concentration in the CAL-51 assay: 16 nM
The estimate for compound 4 lay 2.7-fold (0.43 log units) below the measured number; the measured number lies above the stated range.
By their numbers in the CAL-51 assay, from the lowest: compounds 3, 1, 2 and 4 (each within the scatter of the next, the first and the last beyond it).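

Going by these compounds alone, on the carbonyl carbon itself the exchange is not neutral in the CAL-51 assay: the group with 2 four-membered non-aromatic rings weakens inhibition by a modest step beyond the scatter (a 3.2-fold higher number from compound 3 to compound 4 (0.51 log units; beyond the scatter)), the first such step at this part of the molecule. Compound 4 nevertheless cannot be told apart from compound 2, which lacks the carbonyl altogether (a 1.8-fold higher number from compound 2 to compound 4 (0.25 log units; within the scatter)), so the loss holds only against compound 3 and does not set compound 4 apart from every other compound with the same lactam-free comparison in view. In a physicochemical assay for solubility, read by HPLC, in phosphate buffer, measured as kinetic solubility, with a stated time of 24 h, at pH 7.4, tested at 200 uM (on this read-out higher numbers stand for higher solubility and lower numbers for lower solubility), compound 3 gives 800 nM and compound 4 gives 180000 nM on the same read-out. The same exchange moves the solubility read-out far more than the cell read-out, a large rise in the physicochemical assay set against a modest loss of inhibition: the measured solubility of compound 3, 800 nM, and of compound 4, 180000 nM, a 230-fold higher number (2.35 log units; beyond the scatter)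

Whether this large rise and modest loss belong to the two four-membered rings in particular stays open, as only two groups on this carbonyl carbon are shown. A morpholin-4-yl group or a plain dimethylamino group in the same place would show whether the two read-outs can move apart further or whether solubility can rise with no loss of inhibition at all.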